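This account rests on a few compounds, and the source may have more. Where it says the series, first, only, none or still open, it means among the compounds named here.

Compound 1, `COc1ccc(F)cc1CNCCCNc1ccnc2cc(Oc3ccc(F)cc3)ccc12`, gives 14500 nM in a physicochemical assay for solubility, with a stated time of 18 h, at pH 7.4; a higher number here means a more soluble compound, a lower number a less soluble compound. Compound 2, `COc1ccc(F)cc1CNCCCNc1ccnc2cc(Oc3cccc(N(C)C)c3)ccc12`, gives 14500 nM in this assay. Compound 3, `COc1cccc(CNCCCNc2ccnc3cc(Oc4cccc(N(C)C)c4)ccc23)c1O`, gives 14500 nM in this assay.

Compounds 2 and 1 differ by one change, (4-fluorophenyl in place of 3-(dimethylamino)phenyl on an oxygen on an aromatic ring), and the step of no change at the digits printed from compound 2 to compound 1 (within the scatter). The cores of compounds 2 and 3 differ in another way, (2-hydroxy-3-methoxyphenyl in place of 5-fluoro-2-methoxyphenyl on a saturated chain carbon bound to an amine nitrogen), and that step also no change at the digits printed from compound 2 to compound 3 (within the scatter). Compound 3 thus sits level with compounds 1 and 2 in this assay, with all three values inside the usual scatter of one another.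

Compound 4, `COc1cccc(CNCCCNc2ccnc3cc(Oc4ccc(F)cc4)ccc23)c1O`, has not yet been measured in this assay. It arises from compound 3 by the change (4-fluorophenyl in place of 3-(dimethylamino)phenyl on an oxygen on an aromatic ring). This is the same change that carried compound 2 to compound 1, at a place described in the same words, so among these compounds it occurs twice. For compound 4 the step of no change at the digits printed from compound 3 to compound 4 (within the scatter) is expected, because the same change gave no change at the digits printed from compound 2 to compound 1 (within the scatter) on the other core. Compound 4 is therefore estimated at 14500 nM, between 7000 nM and 25000 nM.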

Compound 4, solubility: 14500 nM
For compound 4 middle estimate and measured number coincide at the digits printed; the measured number falls inside the stated range.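

In this assay the replacement of 3-(dimethylamino)phenyl by 4-fluorophenyl on an oxygen on an aromatic ring reads no change at the digits printed from compound 3 to compound 4 (within the scatter) and on the other core reads no change at the digits printed from compound 2 to compound 1 (within the scatter) as well, so the change behaves alike on the two cores shown. The second change in the set, 2-hydroxy-3-methoxyphenyl in place of 5-fluoro-2-methoxyphenyl on a saturated chain carbon bound to an amine nitrogen, agrees in the same way, with no change at the digits printed from compound 1 to compound 4 (within the scatter) matching no change at the digits printed from compound 2 to compound 3 (within the scatter) in this four-compound square. For the compounds shown here, this shows only that two null steps repeat on two cores; with no step beyond the scatter, no effect of any size has been carried across, and the result cannot show that a change that moves the number would transfer.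

Nothing given here bears on why the four values coincide. Going by these compounds alone, it remains open whether a carboxylic acid in place of the 4-fluorophenyl, or a longer chain than the one these compounds share, would give a step beyond the scatter in this assay and whether that step would repeat on both cores.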